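This account rests on a few compounds, and the source may have more. Where it says the series, first, only, none or still open, it means among the compounds named here.

Measured in a functional assay on HT-29 cells (Homo sapiens) for antiproliferative activity, read by sulforhodamine B assay, with a stated time of 72 h (a higher number here means a weaker inhibitor, a lower number a stronger inhibitor), each entry being a limit of the assay:

- Compound 1 `COc1ccccc1NC(=S)N/N=C/c1ccc2ccccc2n1`: > 100000 nM
- Compound 2 `COc1ccc(C)cc1NC(=S)N/N=C/c1ccc2ccccc2n1`: > 100000 nM
- Compound 3 `Cc1cccc(NC(=S)N/N=C/c2ccc3ccccc3n2)c1`: > 100000 nM

In this assay compound 3 gives > 100000 nM, which is a limit and not a number. It shares this position with both other compounds, as the limit of > 100000 nM in this assay, at which 3 of the 3 values shown sit, records, so the series offers no measured number to build on.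

The next compound is compound 4 `S=C(N/N=C/c1ccc2ccccc2n1)Nc1cccc(Br)c1`, which carries bromo in place of methyl on an aromatic carbon, meta to a large group: bromo in place of methyl on an aromatic carbon. The aryl group is thus changed from 3-methylphenyl to 3-bromophenyl. For the measured compounds named here, no measured step makes this exchange. The nearest are those that alter substituents on the same aryl group: a step that the two limits leave unreadable from compound 1 to compound 3, a step that the two limits leave unreadable from compound 2 to compound 3 and a step that the two limits leave unreadable from compound 1 to compound 2. None has a readable size, so none supplies a size or a direction to carry over. The only expectation they support is that compound 4 stays in the same region of this assay, quite possibly reported as a limit again. The estimated change is a number no higher from compound 3 to compound 4 (the limit leaves the size open), with no step beyond the scatter expected.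

For compound 4 the expected value is 100000 nM, with an estimated range from 20000 nM to 200000 nM.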

Compound 4, half-maximal inhibitory concentration: 58900 nM
For compound 4 the middle estimate is 1.7-fold (0.23 log units) above the measured one; the range from low to high includes it.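

In this assay compound 4 gives 58900 nM, so at this position, meta to a large group, 3-bromophenyl yields the first value in the series that is a number and not a limit: the limit of > 100000 nM in this assay, at which 3 of the 4 values shown sit.

The exchange of methyl for bromo is an at least 1.6-fold lower number from compound 3 to compound 4 (0.22 log units; that floor lies within the scatter), and the replacement of the 2-methoxyphenyl group by 3-bromophenyl is an at least 1.6-fold lower number from compound 1 to compound 4 (0.22 log units; that floor lies within the scatter). Both figures are only floors that lie within the scatter, so neither step establishes a real gain, and the steps among the three earlier compounds cannot be read at all.

The compounds shown leave open whether another group on this aromatic carbon, such as chloro, trifluoromethyl or an amine, would also give a number rather than a limit, and whether bromo on a different carbon of the same ring would do so. For the compounds shown here, with only one number, they also leave open how far compound 4 truly stands from the other compounds, and so how large this change is.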